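Aryl change in a series held at the assay limit

This account rests on a few compounds, and the source may have more. Where it says the series, first, only, none or still open, it means among the compounds named here.

Measured so far in a functional assay on HepG2 cells (Homo sapiens) for antiproliferative activity, read by spectrophotometry, with a stated time of 2 days; a higher number here means a weaker inhibitor of growth, a lower number a stronger inhibitor of growth
- compound 1 `Cc1ccc(Nc2ncc(C(F)(F)F)c(N3Cc4cccc(N(C)S(C)(=O)=O)c4C3)n2)cc1C` gives > 30000 nM (a limit)
- compound 2 `Cc1ccc(Nc2ncc(C(F)(F)F)c(N3Cc4cccc(N(C)S(C)(=O)=O)c4C3)n2)c(Cl)c1` gives > 30000 nM (a limit)

In this assay compound 2 gives > 30000 nM, and this is a limit. Both measured compounds stand at the limit of > 30000 nM in this assay, at which 2 of the 2 values shown sit, so the position of compound 2 has no readable size.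

Compound 3 `Cc1cc(F)ccc1Nc1ncc(C(F)(F)F)c(N2Cc3cccc(N(C)S(C)(=O)=O)c3C2)n1` differs from compound 2 by 4-fluoro-2-methylphenyl in place of 2-chloro-4-methylphenyl on a nitrogen on an aromatic ring, with the change on a nitrogen on an aromatic ring. Within the data shown here, the one measured step at this place is a step that the two limits leave unreadable from compound 1 to compound 2, which gives no size to carry over. No shift beyond the scatter is therefore expected in this assay, and no direction can be assigned. The expected change is a number no higher from compound 2 to compound 3 (the limit leaves the size open) as an estimate. For compound 3 the estimated value is 30000 nM, with an expected range from 12000 nM to 60000 nM, and a report as a limit is likely.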

Compound 3, concentration for 50% growth inhibition: 16800 nM
Beside the measured number, compound 3's estimate is 1.8-fold (0.25 log units) above it; the range from low to high includes it.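

In this assay compound 3 gives 16800 nM, the only number among the three compounds shown, so this position on the nitrogen now has one aryl group that can be read as a value rather than a limit. As far as these compounds go, the change reads as an at least 1.7-fold lower number from compound 2 to compound 3 (0.25 log units; that floor lies within the scatter) and, against the other aryl group, as an at least 1.7-fold lower number from compound 1 to compound 3 (0.25 log units; that floor lies within the scatter); both are floors, so their true size stays open and no shift beyond the scatter is established. The step between compound 1 and compound 2 cannot be read, since both stand at a limit: the limit of > 30000 nM in this assay, at which 2 of the 3 values shown sit.

The compounds shown do not separate the contribution of the fluorine from that of the methyl in 4-fluoro-2-methylphenyl. From the compounds shown here alone, how a phenyl ring carrying an amine or a carboxylic acid would read at this position in this assay also remains open.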